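The compounds below may be only part of what the source reports. "The series", "measured", "known", "first", "only" and "open" are said of these compounds alone.

Of the compounds shown here, two of a shared core have been tested in a functional assay on CRL2813 cells (Homo sapiens) for cytotoxicity, read by sulforhodamine B assay, with a stated time of 5 days; on this read-out lower numbers stand for stronger inhibition and higher numbers for weaker inhibition. Compound 1 `O=C(Nc1cccc(C(F)(F)F)c1)N[C@H]1CC[C@H](Oc2cccc(C(F)(F)F)c2)CC1` gives 1300 nM. For compound 2 `CSc1ccccc1NC(=O)N[C@H]1CC[C@H](Oc2ccc(F)cc2)CC1` this assay reports a limit rather than a number, > 20000 nM. Compound 2 thus stands at the limit of > 20000 nM in this assay, at which 1 of the 2 values shown sits, the weaker end of what has been measured, while compound 1 lies inside the measurable range.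

Compound 3 `O=C(Nc1ccccc1)N[C@H]1CC[C@H](Oc2ccc(F)cc2)CC1` has not yet been measured. It differs from compound 2 in one place: hydrogen in place of methylsulfanyl on an aromatic carbon. Among the compounds with values here, no step between two measured compounds is available, so nothing measured tells how large such a change is in this assay. Because compound 2 sits at the limit of > 20000 nM in this assay, at which 1 of the 2 values shown sits, the result for compound 3 is expected to stay near that limit, with the step of a number no higher from compound 2 to compound 3 (the limit leaves the size open) estimated as no more than the usual scatter. Compound 3 is therefore expected at about 20000 nM, within the range 5000 nM to 60000 nM.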

Compound 3, half-maximal inhibitory concentration: 20000 nM
Beside the measured number, compound 3's estimate shows no gap at the digits printed; low and high end bracket the measured number.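

In this assay, compound 2 carries only a limit, > 20000 nM. Compound 3, with phenyl in place of 2-(methylsulfanyl)phenyl, gives an actual number, 20000 nM, so this aromatic carbon can lose methylsulfanyl and the compound still reads on the scale. The step reads a number no higher from compound 2 to compound 3 (the limit leaves the size open). The size of the change cannot be read, because one end of the step is not a number: the limit of > 20000 nM in this assay, at which 1 of the 3 values shown sits.

The compounds shown leave open how this assay would respond to other groups on this aromatic carbon, such as an amine, a carboxylic acid or a longer chain. They also leave open what methylsulfanyl does here when both ends of the step can be read as numbers.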